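Swapping an oxetane for a methoxymethyl chain

A few compounds are considered here, and "the series" means these few. Any claim that something is new, unique, unknown or untested is made for them only; others in the source may bear on it.

Compound 1 `CC(C)(C#N)CC#Cc1c(Cl)c2c(Cl)cc(C(N)=O)nc2n1[C@H]1CCCNC1`: 113 nM
Compound 2 `CC1(CC#Cc2c(Cl)c3c(Cl)cc(C(N)=O)nc3n2[C@H]2CCCNC2)COC1`: 289 nM

Both compounds were tested in a functional assay on KG-1 cells (Homo sapiens) for antiproliferative activity; a lower number here means that less compound is needed, a higher number that more compound is needed for the effect. Within the data shown here, compound 2 gives the higher of the two numbers; its only neighbour is compound 1, and the single measured step, a 2.6-fold higher number from compound 1 to compound 2 (0.41 log units; beyond the scatter), is a modest rise beyond the scatter when the group on the saturated chain carbon bound to the triple-bonded carbon is exchanged.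

Compound 3, `COCCC#Cc1c(Cl)c2c(Cl)cc(C(N)=O)nc2n1[C@H]1CCCNC1`, has not yet been measured. It differs from compound 2 by methoxymethyl in place of 3-methyloxetan-3-yl on a saturated chain carbon bound to a triple-bonded carbon. Among the measured compounds shown here, the one measured step concerns the same position but a different pair of groups, so it bears only loosely on this change: it shows that an exchange at this position shifted the number by a modest amount, and nothing in the data shows which direction a switch to a small open chain takes. The expected step of a 1.3-fold lower number from compound 2 to compound 3 (0.12 log units; within the scatter) is therefore estimated to be small and without a clear direction. Compound 3 is estimated at 220 nM, with a range from 80 nM to 600 nM.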

Compound 3, half-maximal effective concentration: 39 nM
Estimate against measurement, compound 3: 5.6-fold (0.75 log units) above; the whole stated range lies above it.
By their numbers in this assay, from the lowest: compound 3; then compound 1; then compound 2.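

In this assay, the position on the saturated chain carbon bound to a triple-bonded carbon now proves able to move the number downward as well as upward: replacing 3-methyloxetan-3-yl with methoxymethyl gives a 7.4-fold lower number from compound 2 to compound 3 (0.87 log units; beyond the scatter), and replacing the 1-cyano-1-methylethyl group with methoxymethyl gives a 2.9-fold lower number from compound 1 to compound 3 (0.46 log units; beyond the scatter). Both steps lie beyond the scatter, so compound 3 has the lowest number of the three, and the open methoxymethyl group is the only one here that takes the number below that of compound 1. Compounds 2 and 3 each carry one hydrogen-bond acceptor and no donor, so those counts alone do not set the number, and nothing available explains why the change has this effect.

This change removes the ring and shortens the group at once, so the compounds shown cannot separate the two, nor say whether the oxygen matters at all. A plain hydrocarbon chain such as propyl, a longer ether such as ethoxymethyl, or an amine such as dimethylaminomethyl at the same place would each leave a different part of that question open to test.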